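The source may hold more compounds than are shown below. What is called first, only, known or untested is meant among the compounds shown, and "the series" means these compounds.

Three amides sharing one core were examined in a functional assay on SMMC-7721 cells (Homo sapiens) for inhibition, read by CCK-8 assay, with a stated time of 72 h, tested at 2 uM; on this read-out lower numbers stand for less inhibition of growth and higher numbers for more inhibition of growth at the one concentration tested. Compound 1 `Nc1ccccc1NC(=O)/C=C/c1ccc(CSc2ccc(Cl)cc2)cc1` gave 15.2%, and compound 2 `Nc1ccccc1NC(=O)/C=C/c1ccc(CSc2ccc(F)cc2)cc1` gave 18.3%. These two differ by a single change, (chloro in place of fluoro on an aromatic carbon), and that change made a step of a number 3.1 percentage points lower from compound 2 to compound 1 (within the scatter). Compound 3 `Nc1ccccc1NC(=O)c1ccc(CSc2ccc(F)cc2)cc1` gave 6.58%, the lowest of the three numbers; its gap to compound 1 is within the scatter, while compound 2 stands higher by a margin beyond it. The difference between the core of compound 3 and the core of compound 2 is not broken down here. Compound 4 `Nc1ccccc1NC(=O)c1ccc(CSc2ccc(Cl)cc2)cc1` has not yet been measured. Going by the values given here, it differs from compound 3 by chloro in place of fluoro on an aromatic carbon, the same change as the one separating compound 2 and compound 1, sitting at a place described in the same words. A small step is therefore expected, a number 1.6 percentage points lower from compound 3 to compound 4 (within the scatter), because a number 3.1 percentage points lower from compound 2 to compound 1 (within the scatter) lay within the scatter. Compound 4 is estimated at 5%. The expected range for compound 4 runs from 0% to 15%.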

Compound 4, percent growth inhibition at one concentration: 2.93%
The estimate for compound 4 lay 2.1 percentage points above the measured number; the range from low to high includes it.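

In this assay the change from 4-fluorophenyl to 4-chlorophenyl gives a number 3.7 percentage points lower from compound 3 to compound 4 (within the scatter) and so behaves on this core as it did on the core of compound 2, the two steps agreeing: the same change on two cores in this assay, a number 3.1 percentage points lower (within the scatter) from compound 2 to compound 1 and a number 3.7 percentage points lower (within the scatter) from compound 3 to compound 4, 0.6 percentage points apart, within the scatter of two such steps. On these two cores, then, the change carries over as a small step that cannot be told apart from the scatter, and neither pair separates chloro from fluoro. This does not show that the change would stay this small on a third core, and it says nothing about growth inhibition at any other concentration or in any other cell line.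

The compounds shown carry only fluoro or chloro on this aromatic carbon, so what a bromo, a methoxy or an amine would do there remains open. Also open, on these data alone, is how the series would respond if an oxygen replaced the sulfur of the sulfanyl link, or if a longer chain joined the two aromatic rings.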